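Phenyl in Place of Furan-3-yl: What to Expect

The compounds below may be only part of what the source reports. "The series", "measured", "known", "first", "only" and "open" are said of these compounds alone.

Compound 1 `O=c1[nH]cnc2c1c(-c1ccoc1)cn2[C@@H]1O[C@H](CO)[C@@H](O)[C@H]1O` and compound 2 `Nc1nc2c(c(-c3ccoc3)cn2[C@@H]2O[C@H](CO)[C@@H](O)[C@H]2O)c(=O)[nH]1` share one core and differ at a single aromatic carbon. In a functional assay on K562 cells (Homo sapiens), read by MTT assay, with a stated time of 72 h (a lower number here means a stronger inhibitor, a higher number a weaker inhibitor), compound 1 gives 14500 nM, and compound 2 gives 12500 nM. On the two numbers shown, compound 1 and compound 2 sit side by side: the step of a 1.2-fold lower number from compound 1 to compound 2 (0.06 log units; within the scatter). Among the measured compounds shown here, that change, amino in place of hydrogen on an aromatic carbon, is the only measured step available.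

Compound 3 `O=c1[nH]cnc2c1c(-c1ccccc1)cn2[C@@H]1O[C@H](CO)[C@@H](O)[C@H]1O` has not been measured. It differs from compound 1 in one place: phenyl in place of furan-3-yl on an aromatic carbon. For the measured compounds named here, the one measured step concerns a different position and a different kind of change, so it offers no direct guide here, and no measured pair swaps one aromatic ring for another. Both measured numbers lie close together, and with nothing to show otherwise, compound 3 is expected to stay near the level of compound 1. For compound 3 the estimate in this assay is therefore 15000 nM, with a range from 5000 nM to 45000 nM, and the step of a 1.0-fold higher number from compound 1 to compound 3 (0.01 log units; within the scatter) is expected to lie within the scatter.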

Compound 3, half-maximal inhibitory concentration: > 20000 nM
Compound 3 was reported as a limit (the forecaster's own chance of this, stated with the estimate: 10%); middle value at least 1.3-fold (0.12 log units) away from the limit.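

In this assay compound 3 is reported as > 20000 nM, which is a limit and not a number. This is the first change shown at the aromatic carbon that carries furan-3-yl, and replacing that five-membered ring with phenyl gives an at least 1.3-fold higher number from compound 1 to compound 3 (0.13 log units; that floor lies within the scatter), so the swap brings no sign of a stronger inhibitor, although the smallest difference the limit allows is no larger than ordinary scatter. The size of the step therefore stays unknown, and the reading stops at the limit: the limit of > 20000 nM in this assay, at which 1 of the 3 values shown sits.

The compounds shown leave open how far compound 3 really lies from compound 1, and a single swap cannot tell whether the ring oxygen of furan-3-yl, the ring size or something else matters on this carbon. Also open, from the compounds shown here alone, is how thiophen-3-yl, pyridin-3-yl or a simple amine would read on this same carbon, and whether phenyl would behave the same way on the core of compound 2, which carries the amino group.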